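Dichlorophenyl amide variant of compound 2: expected efficacy

The compounds below may be only part of what the source reports. "The series", "measured", "known", "first", "only" and "open" are said of these compounds alone.

Three compounds carry numbers in a functional assay on HEK293 cells for agonist activity at D(4) dopamine receptor (Homo sapiens), read by FLIPR; on this read-out higher numbers stand for larger maximal responses and lower numbers for smaller maximal responses. Compound 1 `Cc1cc(C)cc(NC(=O)CN2CCC(c3cccc[n+]3[O-])CC2)c1` gives 76% in this assay. Compound 2 `Cc1cc(C(=O)NCN2CCC(c3cccc[n+]3[O-])CC2)ccc1F` gives 67% in this assay. Compound 3 `Cc1cccc(NC(=O)CN2CCC(c3cccc(C#N)n3)CC2)c1` gives 42% in this assay. Compound 2 stands second highest of the three: the nearest number belongs to compound 1, which lies higher but within the scatter, so no order between compound 1 and compound 2 can be claimed; compound 3 lies below compound 2 by a gap beyond the scatter.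

Compound 4 `O=C(NCN1CCC(c2cccc[n+]2[O-])CC1)c1cc(Cl)cc(Cl)c1` has no number yet in this assay. It differs from compound 2 in one place: 3,5-dichlorophenyl in place of 4-fluoro-3-methylphenyl on a carbonyl carbon. The amide-type nitrogen and the rest of the shared core are unchanged. Within the data shown here, no measured pair shows this change, so the data give no direction for it. The expected step in this assay is a number 2 percentage points lower from compound 2 to compound 4 (within the scatter), none beyond the scatter. Compound 4 is estimated to give 65%, with a range from 45% to 85%.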

Compound 4, largest response reached (reported as efficacy), in percent of the reference or control that the assay uses: 64%
Compound 4: the middle estimate sits 1 percentage points above what was measured; low and high end bracket the measured number.
By their numbers in this assay, from the lowest: compound 3; then compounds 4, 2 and 1 (each within the scatter of the next, the first and the last beyond it).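

On the carbonyl carbon whose other neighbour is the amide-type nitrogen, the series now has its first one-place comparison in this assay: 3,5-dichlorophenyl in place of 4-fluoro-3-methylphenyl gives a number 3 percentage points lower from compound 2 to compound 4 (within the scatter). At this position, the two substituted phenyl groups therefore cannot be told apart on this read-out, so a fluorine and methyl pattern is not required for a maximal response of this size. Nothing measured on these compounds bears on a cause for this result.

On these data alone, it remains open whether this holds for groups of another kind on the carbonyl carbon, such as an unsubstituted phenyl, a pyridine ring or a phenyl carrying a carboxylic acid. Also open, as far as these compounds go, is whether the same exchange reads alike on the core of compound 1 or compound 3.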